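Amino in place of iodo on a fluorinated compound

This account rests on a few compounds, and the source may have more. Where it says the series, first, only, none or still open, it means among the compounds named here.

Values in a functional assay on LOX cells (Homo sapiens) for antiproliferative activity, read by WST assay, with a stated time of 3 days; on this read-out lower numbers stand for stronger inhibition and higher numbers for weaker inhibition:
Compound 1 `O=c1cc(I)n([C@@H]2O[C@H](CO)[C@@H](O)[C@H]2O)c(=O)[nH]1`: > 50000 nM
Compound 2 `Nc1cc(=O)[nH]c(=O)n1[C@@H]1O[C@H](CO)[C@@H](O)[C@H]1O`: > 50000 nM
Compound 3 `O=c1[nH]c(=O)n([C@@H]2O[C@H](CO)[C@@H](O)[C@H]2O)c(I)c1F`: > 50000 nM

Compound 3 stands at > 50000 nM, which is a limit and not a number. It has company there: the limit of > 50000 nM in this assay, at which 3 of the 3 values shown sit. Compound 4 `Nc1c(F)c(=O)[nH]c(=O)n1[C@@H]1O[C@H](CO)[C@@H](O)[C@H]1O` puts amino in place of the iodo group of compound 3, next to the ring nitrogen and ortho to a fluoro group: amino in place of iodo on an aromatic carbon. Within the data shown here, two measured steps bear on this, the same swap without the fluoro group, a step that the two limits leave unreadable from compound 1 to compound 2, and the fluoro group alone, a step that the two limits leave unreadable from compound 1 to compound 3. Neither gives a size, so no step beyond the scatter is expected in this assay. The estimated step is a number no higher from compound 3 to compound 4 (the limit leaves the size open). For compound 4 the estimate is 50000 nM, with an expected range of 15000 nM to 100000 nM.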

Compound 4, half-maximal inhibitory concentration: 3400 nM
The estimate for compound 4 lay 15-fold (1.17 log units) above the measured number; the measured number lies below the stated range.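

In this assay, amino in place of iodo gives an at least 14-fold lower number from compound 3 to compound 4 (1.16 log units; beyond the scatter), and fluoro in place of hydrogen gives an at least 14-fold lower number from compound 2 to compound 4 (1.16 log units; beyond the scatter). Among these compounds, a measurable number therefore appears only when amino and fluoro are present together, something the earlier steps from compound 1 could not show, as they cannot be read. The other three values are limits, not numbers: the limit of > 50000 nM in this assay, at which 3 of the 4 values shown sit.

On these data alone, the full size of both steps stays open. So does what a methylamino group in place of amino, or chloro in place of fluoro, would give in this assay.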